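Replacing an aryl substituent with ethoxy on the shared core

A few compounds are considered here, and "the series" means these few. Any claim that something is new, unique, unknown or untested is made for them only; others in the source may bear on it.

Compound 1 `CC(C)(C)n1cc2c(n1)C(=O)CC1(CCN(C(=O)c3cc(-c4ccccc4)nc4ccccc34)CC1)O2`: 2110 nM
Compound 2 `CC(C)(C)n1cc2c(n1)C(=O)CC1(CCN(C(=O)c3cc(-c4ccccc4Cl)nc4ccccc34)CC1)O2`: a limit, > 10000 nM
Compound 3 `CN(C)c1ccc(-c2cc(C(=O)N3CCC4(CC3)CC(=O)c3nn(C(C)(C)C)cc3O4)c3ccccc3n2)cc1`: 1730 nM

In a functional assay on HepG2 cells (Homo sapiens) for inhibition, read by MTT assay, with a stated time of 72 h (on this read-out higher numbers stand for weaker inhibition and lower numbers for stronger inhibition), compound 3 gives 1730 nM, the lowest of the two numbers shown, with compound 1 nearest at a 1.2-fold lower number from compound 1 to compound 3 (0.09 log units; within the scatter). Compound 2 shows only a limit, (the limit of > 10000 nM in this assay, at which 1 of the 3 values shown sits). Compound 4 `CCOc1cc(C(=O)N2CCC3(CC2)CC(=O)c2nn(C(C)(C)C)cc2O3)c2ccccc2n1` differs from compound 3 by ethoxy in place of 4-(dimethylamino)phenyl on an aromatic carbon. Of the measured steps, an at least 5.7-fold lower number from compound 2 to compound 3 (0.76 log units; beyond the scatter) bears on it most, while a 1.2-fold lower number from compound 1 to compound 3 (0.09 log units; within the scatter) shows little from the dimethylamino group alone. Among the compounds with values here, no step removes the whole aromatic group, so compound 4 is expected to lose somewhat, by a 2.6-fold higher number from compound 3 to compound 4 (0.42 log units; beyond the scatter). Compound 4 is estimated at 4500 nM, between 1200 nM and 15000 nM.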

Compound 4, half-maximal inhibitory concentration: > 10000 nM
Compound 4: a limit, no number; the forecaster's own chance of this, stated with the estimate: 30%; middle value at least 2.2-fold (0.34 log units) from the limit.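

In this assay, ethoxy in place of the aryl group on this aromatic carbon next to the ring nitrogen gives an at least 5.7-fold higher number from compound 3 to compound 4 (0.76 log units; beyond the scatter) and an at least 4.7-fold higher number from compound 1 to compound 4 (0.67 log units; beyond the scatter). The value of compound 4 is a limit, and so is that of compound 2: the limit of > 10000 nM in this assay, at which 2 of the 4 values shown sit. The step between these two compounds cannot be read.

The compounds shown leave open whether an aromatic ring at this position is what counts. A cyclohexyl group, a benzyloxy group or a longer alkoxy chain on this carbon would bear on that question.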